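Replacing the 4-Aminophenyl Group in Compound 2

This account rests on a few compounds, and the source may have more. Where it says the series, first, only, none or still open, it means among the compounds named here.

Of the compounds shown here, two sharing one core have been measured so far. In a functional assay on A549 cells (Homo sapiens) for antiproliferative activity, read by MTT assay, with a stated time of 48 h (on this read-out higher numbers stand for weaker inhibition and lower numbers for stronger inhibition), compound 1 (`COc1cc(-c2cccc3nc(-c4ccc(Cl)cc4)oc23)cc(OC)c1OC`) gives 5600 nM and compound 2 (`COc1cc(-c2cccc3nc(-c4ccc(N)cc4)oc23)cc(OC)c1OC`) gives 720 nM, the lower of the two numbers. The next compound to be measured, compound 3 (`COc1cc(-c2cccc3nc(-c4ccc5cc[nH]c5c4)oc23)cc(OC)c1OC`), changes the same group of compound 2: 1H-indol-6-yl in place of 4-aminophenyl on an aromatic carbon. In words, 1H-indol-6-yl stands in place of 4-aminophenyl on an aromatic carbon.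

For the measured compounds named here, only one measured step bears on this change. That step, a 7.8-fold lower number from compound 1 to compound 2 (0.89 log units; beyond the scatter), is modest but beyond the scatter, and it came with amino in place of chloro. It shows that a change at this place can move the number, but it does not replace one whole group with another of this kind, so it offers only indirect guidance. No step beyond the scatter is therefore expected in this assay, with a slight lean towards a higher number. The expected change is a 1.4-fold higher number from compound 2 to compound 3 (0.14 log units; within the scatter). Compound 3 is estimated at 1000 nM, with an expected range from 250 nM to 4000 nM.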

Compound 3, half-maximal inhibitory concentration: 55 nM
The estimate for compound 3 lay 18-fold (1.26 log units) above the measured number, and the stated range ends above it.
By their numbers in this assay, from the lowest: compound 3; then compound 2; then compound 1.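

Compound 2 and compound 1 differ only in the group carried on a phenyl ring that both retain, whereas this change replaces the whole 4-aminophenyl group on the aromatic carbon of the shared core. In this assay, a fused 1H-indol-6-yl group at this place is not merely tolerated but gives a 13-fold lower number from compound 2 to compound 3 (1.12 log units; beyond the scatter), a large step beyond the scatter that the earlier step among phenyl-bearing compounds could not have shown; set against the 4-chlorophenyl group, the same 1H-indol-6-yl group gives a 100-fold lower number from compound 1 to compound 3 (2.01 log units; beyond the scatter), which places it lowest of the three groups compared here, with its steps to both others beyond the scatter. No measurement available here accounts for why this exchange lowers the number so strongly.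

Going by these compounds, it remains open whether the ring nitrogen hydrogen of the 1H-indol-6-yl group matters or whether the fused two-ring shape alone carries the step, a question that a 1-methylindol-6-yl, benzofuran-6-yl or naphthalen-2-yl group at this place would address. The compounds shown also leave open how far the result depends on the point of attachment, as a 1H-indol-5-yl group would show, and whether it extends beyond this assay to other cell lines.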